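A few compounds are considered here, and "the series" means these few. Any claim that something is new, unique, unknown or untested is made for them only; others in the source may bear on it.

Measured so far:
compound 1, `CC(C)Cc1cc2oc(=O)n(CCC(=O)O)c2cc1Cl`: < 10 nm/s
compound 2, `C[C@@H](Oc1cc2oc(=O)n(CCC(=O)O)c2cc1Cl)c1cccnn1`: < 3 nm/s

In a physicochemical assay for permeability, using PAMPA (a higher number here means that the compound crosses the layer faster, a lower number that the compound crosses the layer more slowly), compound 1 gives < 10 nm/s, which is a limit of the assay and not a number. Compound 2 gives < 3 nm/s in this assay, again a limit. Compound 1 thus stands at the limit of < 10 nm/s in this assay, at which 1 of the 2 values shown sits, with no exact figure known. Compound 3, `COCCOc1cc2oc(=O)n(CCC(=O)O)c2cc1Cl`, is not yet measured; it differs from compound 1 by 2-methoxyethoxy in place of isobutyl on an aromatic carbon. Among the measured compounds shown here, no step between measured compounds exists here, so the change is expected to yield a step that the limit leaves unreadable from compound 1 to compound 3, nothing beyond the scatter. Compound 3 is estimated at 3 nm/s, between 1 nm/s and 10 nm/s.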

Compound 3, apparent permeability: < 3 nm/s
Compound 3 was reported as a limit; the forecaster's own chance of this, stated with the estimate: 75%; the middle value sits exactly at the limit.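

Compound 3 gives [ < 3 nm/s ], a limit and not a number. No step can be read from compound 1 or compound 2 to compound 3. The compounds shown leave open the exact value of each in this assay.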